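The source may report more compounds than this note shows. Statements on the series, on what has been measured and on what is new or still open speak of the compounds shown alone.

In a functional assay on NCI-H23 cells (Homo sapiens) for inhibition, read by sulforhodamine B assay, with a stated time of 48 h (a higher number here means a weaker inhibitor of growth, a lower number a stronger inhibitor of growth), compound 2 (`CCCCCCCCCCCC[C@@H](O)[C@H]1CC[C@H]([C@H](O)CCCCCCCCCCNCc2ccnn2C)O1`) gives 646 nM as the higher of the two measured numbers, while compound 1 (`CCCCCCCCCCCC[C@@H](O)[C@H]1CC[C@H]([C@H](O)CCCCCCCCCCNC(=O)c2ccnn2C)O1`) gives 52.5 nM as the lower. Compound 3 (`CCCCCCCCCCCC[C@@H](O)[C@H]1CC[C@H]([C@H](O)CCCCCCCCCCOC(=O)c2ccnn2C)O1`) differs from compound 2 by ((1-methyl-1H-pyrazol-5-yl)carbonyl)oxy in place of ((1-methyl-1H-pyrazol-5-yl)methyl)amino on a saturated chain carbon, ten or more bonds along the chain from an oxygen on a saturated carbon and a saturated ring carbon and has not yet been measured. Among the compounds with values here, the one relevant measured step is a 12-fold higher number from compound 1 to compound 2 (1.09 log units; beyond the scatter) and it exchanges the carbonyl group for the methyl group on an amine nitrogen. Within the data shown here, compound 3 regains the carbonyl, but no measured step covers its oxygen link. For compound 3 the expected change is a 6.5-fold lower number from compound 2 to compound 3 (0.81 log units; beyond the scatter) and this large step runs toward a lower number. Compound 3 is estimated at 100 nM (range 30 nM to 350 nM).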

Compound 3, concentration for 50% growth inhibition: 11000 nM
Estimate against measurement, compound 3: 110-fold (2.04 log units) below; the measured number lies above the stated range.
By their numbers in this assay, from the lowest: compound 1; then compound 2; then compound 3.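

In this assay, replacing the amide link with the ester link gives a 210-fold higher number from compound 1 to compound 3 (2.32 log units; beyond the scatter), so the carbonyl alone does not preserve the low number at this chain end. The ester also compares poorly with the amine link, with a 17-fold higher number from compound 2 to compound 3 (1.23 log units; beyond the scatter), so the order runs amide, amine, ester, and the atom joining the pyrazole unit to the chain matters as well as the carbonyl. Nothing available explains this order. As far as these compounds go, it remains open how a urea or carbamate link, or a methylated amide nitrogen, would compare.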